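A few compounds are considered here, and "the series" means these few. Any claim that something is new, unique, unknown or untested is made for them only; others in the source may bear on it.

Working notes on the series. Compound 1 `Cc1ccc(S(=O)(=O)N[C@@H](CC(=O)NC(C)(C)C)C(=O)NCCNC(=O)Nc2ccccc2)cc1` carries anilino on a carbonyl carbon of the shared core. In an ADME assay on Karpas-1106P cells (Homo sapiens) for cytotoxicity (on this read-out higher numbers stand for an effect only at larger amounts of compound and lower numbers for an effect already at smaller amounts), compound 1 gives > 11100 nM, which is a limit of the assay and not a number. Compound 2 `Cc1ccc(S(=O)(=O)N[C@@H](CC(=O)NC(C)(C)C)C(=O)NCCNC(=O)c2c(O)cccc2F)cc1` has 2-fluoro-6-hydroxyphenyl in place of anilino on a carbonyl carbon. In this assay compound 2 gives > 11100 nM, again only a limit. Compound 3 `Cc1ccc(S(=O)(=O)N[C@@H](CC(=O)NC(C)(C)C)C(=O)NCCNC(=O)c2ccccc2O)cc1` carries 2-hydroxyphenyl in place of anilino on a carbonyl carbon. In this assay compound 3 gives > 11100 nM, also a limit. Accordingly the steps a step that the two limits leave unreadable from compound 1 to compound 2, a step that the two limits leave unreadable from compound 1 to compound 3 and a step that the two limits leave unreadable from compound 2 to compound 3 cannot be sized; every value so far sits at the limit of > 11100 nM in this assay, at which 3 of the 3 values shown sit.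

Compound 4 `Cc1ccc(S(=O)(=O)N[C@@H](CC(=O)NC(C)(C)C)C(=O)NCCNC(=O)c2cccc(C(F)(F)F)c2)cc1` differs from compound 1 by 3-(trifluoromethyl)phenyl in place of anilino on a carbonyl carbon. Within the data shown here, the steps that bear on this change are a step that the two limits leave unreadable from compound 1 to compound 2 and a step that the two limits leave unreadable from compound 1 to compound 3, both exchanges of the anilino group on the same carbonyl carbon, and neither yields a readable size. Among the measured compounds shown here, no step in this assay has yet moved any compound off the limit, so no step beyond the scatter is expected here either, because all three measured values sit at the limit of > 11100 nM in this assay, at which 3 of the 3 values shown sit. Compound 4 is therefore expected in this assay at about 15000 nM, within a range from 5000 nM to 50000 nM. The step that the limit leaves unreadable from compound 1 to compound 4 is expected to be small, most likely reported once more as a limit.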

Compound 4, half-maximal effective concentration: > 11100 nM
Compound 4 ended at the assay's limit; the forecaster's own chance of this, stated with the estimate: 85%; the middle value is on the limit's open side.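

Compound 4 gives > 11100 nM in this assay, again only a limit. Among these compounds, no step to compound 4 from compound 1, compound 2 or compound 3 can be read: the limit of > 11100 nM in this assay, at which 4 of the 4 values shown sit. The compounds shown leave open whether any group on this carbonyl carbon can bring a readable value in this assay.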